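Pyridine to furan exchange on a shared core

The source may report more compounds than this note shows. Statements on the series, on what has been measured and on what is new or still open speak of the compounds shown alone.

compound 1: `Oc1ccc(-c2cc(-c3ccc(Cl)cc3)nc(-c3cccnc3)c2)cc1` — 29300 nM
compound 2: `Oc1cccc(-c2cc(-c3cccnc3)nc(-c3ccccc3Cl)c2)c1` — "not determined" (no result reported)
compound 3: `Oc1cccc(-c2cc(-c3ccc(Cl)cc3)nc(-c3cccnc3)c2)c1` — 18100 nM

In a functional assay on T47D cells (Homo sapiens) for cytotoxicity, read by CCK-8 assay and cell counting, with a stated time of 2 days (a higher number here means a weaker inhibitor, a lower number a stronger inhibitor), compound 1 gives 29300 nM and compound 3 gives 18100 nM. Among the measured compounds shown here, for compound 2 no result was reported in this assay, so only two numbers stand side by side. Compound 3 has the lower of these two, but the difference to compound 1 is small: a 1.6-fold lower number from compound 1 to compound 3 (0.21 log units; within the scatter), a change that stays within the scatter and is tied to the hydroxyphenyl group alone.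

Compound 4, `Oc1cccc(-c2cc(-c3ccc(Cl)cc3)nc(-c3ccco3)c2)c1`, differs from compound 3 in another place: furan-2-yl in place of pyridin-3-yl on an aromatic carbon. For the measured compounds named here, none of the measured steps touches this group; the only step available, from compound 1 to compound 3, concerns the hydroxyphenyl group and leaves the pyridin-3-yl group in place. There is therefore no measured guide for this exchange, and both measured compounds sit in the same weak region of this assay.

On that basis the step is expected to be a 1.2-fold higher number from compound 3 to compound 4 (0.08 log units; within the scatter), that is, no movement beyond the scatter is expected. Compound 4 is estimated at 22000 nM in this assay, with a range from 7000 nM to 70000 nM.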

Compound 4, half-maximal inhibitory concentration: 10500 nM
Compound 4: middle estimate off by 2.1-fold (0.32 log units), on the high side; the range from low to high includes it.
By their numbers in this assay, from the lowest: compounds 4, 3 and 1 (each within the scatter of the next, the first and the last beyond it).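

In this assay, among the compounds shown here, the exchange of pyridin-3-yl for furan-2-yl, on the aromatic carbon next to the ring nitrogen, gives a 1.7-fold lower number from compound 3 to compound 4 (0.24 log units; within the scatter) and thereby supplies the first reading at this position, where the earlier step had changed only the hydroxyphenyl group. Although a six-membered aromatic ring with a nitrogen gives way to a five-membered aromatic ring with an oxygen, the number stays within the scatter, so this position accepts either ring without a measurable shift in this cell read-out, and neither ring lifts the series out of its weak region. No measurement at hand explains why the two rings read alike.

The compounds shown leave open whether the same exchange would read alike with the 4-hydroxyphenyl group of compound 1, since the furan-2-yl group appears here only beside the 3-hydroxyphenyl group. They also leave open whether a group of another kind at this position, such as a morpholine ring or a short chain ending in an amine, would move the number beyond the scatter.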